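This account rests on a few compounds, and the source may have more. Where it says the series, first, only, none or still open, it means among the compounds named here.

Measured compounds in an ADME assay on HeLa cells (Homo sapiens) for cytotoxicity, read by ATP content, with a stated time of 3 days; on this read-out higher numbers stand for lower toxicity in this test and lower numbers for higher toxicity in this test:
- compound 1 `O=c1n(Cc2cc3cc(Br)ccc3n2CCCCO)c2cnccc2n1C1CC1`: compound 1 gives > 50000 nM
- compound 2 `CS(=O)(=O)CCCn1c(Cn2c(=O)n(C3CC3)c3ccncc32)cc2cc(Br)ccc21`: compound 2 gives > 50000 nM

Compound 1 stands at a limit in this assay: its value of > 50000 nM is a limit of the assay and not a number. For the measured compounds named here, the only other value shown, that of compound 2, is also a limit. Going by the values given here, the one measured step, a step that the two limits leave unreadable from compound 1 to compound 2, is therefore of unreadable size, since both ends sit at the limit of > 50000 nM in this assay, at which 2 of the 2 values shown sit.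

Compound 3 `O=c1n(Cc2cc3cc(F)ccc3n2CCCCO)c2cnccc2n1C1CC1` differs from compound 1 by fluoro in place of bromo on an aromatic carbon. Among the compounds with values here, no measured step touches this part of the shared core, so nothing among the numbers speaks for or against a change in this test. Given that both compounds measured so far reach the limit, compound 3 is expected to behave alike, and the step that the limit leaves unreadable from compound 1 to compound 3 is expected to lie within the scatter. For compound 3 the estimate in this assay is 70000 nM, with a range from 30000 nM to 200000 nM.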

Compound 3, half-maximal cytotoxic concentration: > 50000 nM
Compound 3: only a limit was reported; the forecaster's own chance of this, stated with the estimate: 80%; the middle value is on the limit's open side.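

In this assay compound 3 gives > 50000 nM, which is a limit of the assay and not a number. The step from bromo to fluoro between compound 1 and compound 3 therefore cannot be read: the limit of > 50000 nM in this assay, at which 3 of the 3 values shown sit.

The compounds shown leave open whether fluoro in place of bromo or methylsulfonyl in place of hydroxymethyl changes the half-maximal cytotoxic concentration in this assay at all.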